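The source may report more compounds than this note shows. Statements on the series, on what has been measured and on what is new or still open speak of the compounds shown alone.

Measured so far:
compound 1 `C#CCSc1nc(Sc2nccs2)c(C#N)c(-c2ccc(C)cc2)n1` gives 4300 nM
compound 2 `C=CC(=O)Nc1ccccc1CN(C(=O)Nc1cccc(C(F)(F)F)c1)C1CCN(C(C)CCC)CC1` gives 17900 nM
compound 3 `C#CCSc1nc(Sc2nncs2)c(C#N)c(-c2cc(OC)c(OC)c(OC)c2)n1` gives 8250 nM

In a functional assay on KYSE-70 cells for antiproliferative activity against KYSE-70 cell line (Homo sapiens), read by MTT assay, with a stated time of 72 h (a lower number here means a stronger inhibitor, a higher number a weaker inhibitor), compound 1 gives 4300 nM, the lowest of the three numbers. Compound 3 stands nearest to it, and the gap between those two lies within the scatter, so no order between compound 1 and compound 3 can be read from them. Compound 2 lies furthest away, and that gap is beyond the scatter, so compound 1 is the stronger inhibitor of that pair. Among the measured compounds shown here, the structures are diverse, and no pair among the three differs in a single place, so no step of a defined change has been measured here.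

Compound 4 `C#CCSc1nc(Sc2nccs2)c(C#N)c(-c2ccc[nH]2)n1` shares its core with compound 1 and differs from it in one place: 1H-pyrrol-2-yl in place of 4-methylphenyl on an aromatic carbon

For the measured compounds named here, no measured step bears on this change, so its size and direction rest on judgement alone. An aryl group on the same carbon is kept in compound 3, which with compound 1 shows that a change of that group can leave the number within the scatter. The step of a 1.4-fold higher number from compound 1 to compound 4 (0.14 log units; within the scatter) is therefore expected to be small, possibly a little toward a weaker inhibitor, and not clearly beyond the scatter. Compound 4 is estimated at 6000 nM, within a range from 2000 nM to 20000 nM.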

Compound 4, half-maximal inhibitory concentration: > 20000 nM
Compound 4 was reported as a limit (the forecaster's own chance of this, stated with the estimate: 10%); middle value at least 3.3-fold (0.52 log units) away from the limit.
By their numbers in this assay, from the lowest: compounds 1 and 3 (each within the scatter of the next); then compound 2. At a limit, above all of these: compound 4.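

In this assay compound 4 gives > 20000 nM, which is a limit of the assay and not a number. Among the compounds shown here, no earlier pair differed in one place, so this is the first defined change at this aromatic carbon, ortho to a cyano group, and it shows that the position does not accept every aryl group: putting 1H-pyrrol-2-yl in place of 4-methylphenyl gives an at least 4.6-fold higher number from compound 1 to compound 4 (0.66 log units; beyond the scatter), a loss of inhibition that lies beyond the scatter. The direction of this step is established, but its printed size is only a lower bound, and how much weaker compound 4 really is cannot be read: the limit of > 20000 nM in this assay, at which 1 of the 4 values shown sits.

This single step changes the ring size, the ring atoms and the hydrogen-bond donor count together, and removes the methyl group as well, so the compounds shown leave open which of these differences goes with the loss. From the compounds shown here alone, a plain phenyl, a 2-thienyl or a 1-methylpyrrol-2-yl group on the same carbon would begin to separate them, and whether any group there could give a lower number than compound 1 also remains open.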